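A few compounds are considered here, and "the series" means these few. Any claim that something is new, unique, unknown or untested is made for them only; others in the source may bear on it.

Measured compounds:
compound 1 `Nc1nc(O)c2c(n1)n(C1OC(CO)[C@@H](O)[C@H]1O)c(=O)n2C/C=C/c1ccccc1`, 5%
compound 2 `C=CCn1c(=O)n([C@@H]2O[C@H](CO)[C@H]3OC(CCC)(CCC)O[C@H]32)c2nc(N)nc(O)c21`, 38%

Of the compounds shown here, two have been tested in a functional assay on the whole organism with Mus musculus as the target; a higher number here means a larger maximal response, a lower number a smaller maximal response. Compound 1 gives 5%, the lower of the two numbers. Compound 2 differs from compound 1 in several places. In this assay compound 2 gives 38%. This number lies well above that of compound 1, outside the usual scatter. For the measured compounds named here, no step between compounds differing in a single place is available, so the weight of any one change remains untested.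

Compound 3 `CCOC(=O)Cn1c(=O)n(C2OC(CO)[C@@H](O)[C@H]2O)c2nc(N)nc(O)c21` is the next compound to go into this assay. Compared with compound 1, it carries ethoxycarbonyl in place of 2-phenylethenyl on a saturated chain carbon bound to an aromatic nitrogen. The change removes the longer group and brings in a shorter one with two hydrogen-bond acceptors, on the same chain carbon bound to the aromatic nitrogen.

With compound 2 as the only other reference, the step from compound 1 to compound 3 is expected to be upward and of moderate size, a number 15 percentage points higher from compound 1 to compound 3 (beyond the scatter), though it could stay within the scatter. Compound 3 is therefore estimated at 20% in this assay, with a range from 5% to 45%.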

Compound 3, largest response reached (reported as maximal response), in percent of the reference or control that the assay uses: 58%
Estimate against measurement, compound 3: 38 percentage points below, and the stated range ends below it.
By their numbers in this assay, from the lowest: compound 1; then compound 2; then compound 3.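

In this assay, for the compounds shown here, the exchange of 2-phenylethenyl for ethoxycarbonyl on a saturated chain carbon bound to an aromatic nitrogen gives the first step that changes one place only: a number 53 percentage points higher from compound 1 to compound 3 (beyond the scatter) is large and lies beyond the scatter. The group carried at this position can therefore move the maximal response strongly on its own, with the rest of compound 1 unchanged, and here the shorter ring-free group with hydrogen-bond acceptors goes with the larger response. Nothing among the data shown accounts for this step.

Ethoxycarbonyl differs from 2-phenylethenyl at once in size, in the aromatic ring and in its hydrogen-bond acceptors, so which of these differences matters remains open, and compound 2 differs from the others in several places and cannot settle it. Also open, as far as these compounds go, is how a carboxylic acid, an amide or a longer chain on the same saturated chain carbon would compare with ethoxycarbonyl, and whether the step would hold on a different sugar portion such as that of compound 2.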